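Hydrazone aryl swap in the shared core: compound 4 outlook

This account rests on a few compounds, and the source may have more. Where it says the series, first, only, none or still open, it means among the compounds named here.

Measured so far in a functional assay on PC-3 cells (Homo sapiens) for antiproliferative activity, read by MTT assay; on this read-out higher numbers stand for weaker inhibition and lower numbers for stronger inhibition:
compound 1, `Cc1cccc(/C=N/Nc2ncc3c(n2)n(C2CCCC2)c(=O)c(=O)n3C)c1`, 53600 nM
compound 2, `Cn1c(=O)c(=O)n(C2CCCC2)c2nc(N/N=C/c3ccc(F)cc3Cl)ncc21`, 15200 nM
compound 3, `Cc1ccc(/C=N/Nc2ncc3c(n2)n(C2CCCC2)c(=O)c(=O)n3C)cc1C`, 39000 nM

Compound 3 stands second highest of the three numbers; its nearest neighbour is compound 1, within the scatter, and its furthest is compound 2, which lies beyond the scatter on the lower side. The next compound, compound 4, `Cn1c(=O)c(=O)n(C2CCCC2)c2nc(N/N=C/c3ccc(F)cc3Br)ncc21`, differs from compound 3 in one place: 2-bromo-4-fluorophenyl in place of 3,4-dimethylphenyl on a carbon with a double bond to nitrogen. The step that bears most directly on this change is a 2.6-fold higher number from compound 2 to compound 3 (0.41 log units; beyond the scatter), which is essentially the reverse direction of the present swap, with bromine in place of chlorine on the entering ring. The step of a 3.5-fold lower number from compound 1 to compound 2 (0.55 log units; beyond the scatter) points the same way, a lower number on going to the halogenated ring. The change from compound 3 to compound 4 is therefore expected to give a modest step downward in this assay, about the size of the steps just cited, a 2.6-fold lower number from compound 3 to compound 4 (0.41 log units; beyond the scatter). Compound 4 is estimated at 15000 nM in this assay, with a range from 5000 nM to 45000 nM.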

Compound 4, half-maximal inhibitory concentration: 9250 nM
Compound 4: the middle estimate sits 1.6-fold (0.21 log units) above what was measured; the range from low to high includes it.
By their numbers in this assay, from the lowest: compounds 4 and 2 (each within the scatter of the next); then compounds 3 and 1 (each within the scatter of the next).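

In this assay, the 2-bromo-4-fluorophenyl group on the carbon with a double bond to nitrogen gives a 4.2-fold lower number from compound 3 to compound 4 (0.62 log units; beyond the scatter) and a 5.8-fold lower number from compound 1 to compound 4 (0.76 log units; beyond the scatter) in working terms, so a second halogen-bearing ring now stands clear of both methyl-bearing rings, as compound 2 already did against compound 1 and compound 3. Bromo in place of chloro on an aromatic carbon gives a 1.6-fold lower number from compound 2 to compound 4 (0.22 log units; within the scatter) and so leaves the two halogens indistinguishable at this position, with no order to read between them. Nothing available here explains the gap between the halogen-bearing and methyl-bearing rings.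

The compounds shown leave open whether the lower numbers need both halogens, as a ring carrying fluoro alone or bromo alone would show. From the compounds shown here alone, how a ring carrying an amine or a carboxylic acid would behave at this position also remains open.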